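Chloro to bromo at the low end of a series

This account rests on a few compounds, and the source may have more. Where it says the series, first, only, none or still open, it means among the compounds named here.

Growth inhibition measured in a functional assay on OVCAR-5 cells (Homo sapiens) for inhibition, read by CCK-8 assay, with a stated time of 72 h, tested at 1 uM; a higher number here means more inhibition of growth at the concentration tested, a lower number less inhibition of growth
compound 1 `CN(C)C(=O)c1cc2cnc(Nc3ccc(NC(=O)C4(C(=O)Nc5ccc(F)cc5)CC4)cc3)nc2n1C1CCCC1` gives 65.4%
compound 2 `CN(C)C(=O)c1cc2cnc(Nc3ccc(NC(=O)C4(C(=O)Nc5cccc(F)c5)CC4)cc3)nc2n1C1CCCC1` gives 26.3%
compound 3 `CN(C)C(=O)c1cc2cnc(Nc3ccc(NC(=O)C4(C(=O)Nc5cccc(Cl)c5)CC4)cc3)nc2n1C1CCCC1` gives 15.5%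

Compound 3 stands lowest of the three. Compound 4 `CN(C)C(=O)c1cc2cnc(Nc3ccc(NC(=O)C4(C(=O)Nc5cccc(Br)c5)CC4)cc3)nc2n1C1CCCC1` carries bromo in place of chloro on an aromatic carbon. Among the compounds with values here, the closest precedent is chloro in place of fluoro, a modest step of a number 10.8 percentage points lower from compound 2 to compound 3 (beyond the scatter) on the same kind of ring. The large steps of a number 39.1 percentage points lower from compound 1 to compound 2 (beyond the scatter) and a number 49.9 percentage points lower from compound 1 to compound 3 (beyond the scatter) involve the 4-fluorophenyl group, which plays no part in going from 3-chlorophenyl to 3-bromophenyl. A small change in this assay is therefore expected, probably downward and within the scatter, and a number 2 percentage points lower from compound 3 to compound 4 (within the scatter) is the estimated step. In this assay compound 4 is expected at 13.5% with 3% to 27% as the estimated range.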

Compound 4, percent growth inhibition at one concentration: 0.04%
Beside the measured number, compound 4's estimate is 13.5 percentage points above it, outside the stated range (below it).
By their numbers in this assay, from the lowest: compound 4; then compound 3; then compound 2; then compound 1.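

In this assay, exchanging one halogen for another on this ring still matters at the low end of the series: the change gives a number 15.5 percentage points lower from compound 3 to compound 4 (beyond the scatter) and leaves almost no growth inhibition. Across 3-fluorophenyl, 3-chlorophenyl and 3-bromophenyl the number falls at each step, with a number 26.3 percentage points lower from compound 2 to compound 4 (beyond the scatter) overall, and the distance from the 4-fluorophenyl group grows to a number 65.4 percentage points lower from compound 1 to compound 4 (beyond the scatter) as the lowest point of the series. Nothing measured here gives a reason for this trend. Open, on these data alone, is whether a 3-methylphenyl or 3-methoxyphenyl group continues the fall, and whether 4-bromophenyl recovers inhibition.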